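The source may report more compounds than this note shows. Statements on the series, on what has been measured and on what is new or still open speak of the compounds shown alone.

Measured in a physicochemical assay for lipophilicity, read by HPLC, measured as chromatographic lipophilicity, at pH 7.4; on this read-out higher numbers stand for higher lipophilicity and lower numbers for lower lipophilicity:
- compound 1 `Cc1nnc(N2CCC(C(=O)N3N=CC[C@H]3c3ccccc3)CC2)o1`: 3.2
- compound 2 `O=C(c1cccnc1)N1CCC(C(=O)N2N=CCC2c2ccccc2)CC1`: 2.6
- compound 3 `CC(C)(C)C(=O)N1N=CCC1C1CCOCC1`: 4.1

Compound 2 gives the lowest number of the three at 2.6. Compound 1 and compound 3 both stand higher, beyond the scatter. Going by the values given here, no two measured compounds differ in one place only, so no measured step is available as a guide.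

Compound 4 `O=C(c1c[nH]nn1)N1CCC(C(=O)N2N=CCC2c2ccccc2)CC1` is related to compound 2 by 1H-1,2,3-triazol-4-yl in place of pyridin-3-yl on a carbonyl carbon, with 1H-1,2,3-triazol-4-yl in place of pyridin-3-yl on a carbonyl carbon. A modest fall in this assay is expected, possibly no larger than the scatter. The expected change is a number 0.40 log units lower from compound 2 to compound 4 (beyond the scatter). Compound 4 is estimated at 2.2, with an expected range of 1.7 to 2.7.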

Compound 4, distribution coefficient: 2
Estimate against measurement, compound 4: 0.20 log units above, within the range that was stated.
By their numbers in this assay, from the lowest: compound 4; then compound 2; then compound 1; then compound 3.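

First single-place step in the series: in this assay, 1H-1,2,3-triazol-4-yl in place of pyridin-3-yl on a carbonyl carbon gives a number 0.60 log units lower from compound 2 to compound 4 (beyond the scatter). This position therefore registers a change of aromatic ring on this read-out. The entering ring has 1 hydrogen-bond donor and the leaving ring has 0, but no measurement shown explains the step.

From the compounds shown here alone, whether the step follows the donor or the ring itself stays open; a 1-methyl-1H-1,2,3-triazol-4-yl or a phenyl on this carbonyl carbon would bear on that. Going by these compounds, whether the step carries over to other cores also stays open.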